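The compounds below may be only part of what the source reports. "The series", "measured", "known", "first", "only" and "open" are said of these compounds alone.

Measured in a functional assay on MCF7 cells (Homo sapiens) for antiproliferative activity, read by MTT assay, with a stated time of 72 h; a lower number here means a stronger inhibitor, a higher number a weaker inhibitor:
- Compound 1 `Cc1ccc(-c2cn(C[C@H](O)[C@H]3OC(=O)C(OCc4ccccc4)=C3OCc3ccccc3)nn2)cc1` gives > 100000 nM, which is a limit of the assay and not a number.
- Compound 2 `Cc1ccc(S(=O)(=O)NCc2cn(C[C@H](O)[C@H]3OC(=O)C(OCc4ccccc4)=C3OCc3ccccc3)nn2)cc1` gives 6400 nM.
- Compound 3 `COc1ccc(-c2cn(C[C@H](O)[C@H]3OC(=O)C(OCc4ccccc4)=C3OCc3ccccc3)nn2)cc1` gives 99700 nM.

Of the two real numbers, compound 3 holds the higher, so it is the weaker inhibitor of that pair: the data show a 16-fold higher number from compound 2 to compound 3 (1.19 log units; beyond the scatter).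

Compound 4 `O=C1O[C@H]([C@@H](O)Cn2cc(CCO)nn2)C(OCc2ccccc2)=C1OCc1ccccc1` keeps the shared core, but 2-hydroxyethyl takes the place of 4-methoxyphenyl on an aromatic carbon of the five-membered aromatic ring with 3 nitrogen: 2-hydroxyethyl in place of 4-methoxyphenyl on an aromatic carbon.

Changes at this same carbon have already mattered. Within the data shown here, the data show an at least 15-fold lower number from compound 1 to compound 2 (1.19 log units; beyond the scatter), a large step that, with the one from compound 2 above, shows this place can move the number strongly. The group that gave the lower number in compound 2 has little in common with 2-hydroxyethyl, however, so that gain cannot simply be carried over. Going by these compounds, the comparison of the two compounds with a substituted phenyl group gives a number no higher from compound 1 to compound 3 (the limit leaves the size open), and its size stays open.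

A small drop in the number is therefore expected, with a real chance of little change. The expected step is a 1.8-fold lower number from compound 3 to compound 4 (0.26 log units; within the scatter). For compound 4 the estimated value is 55000 nM. The expected range for compound 4 runs from 10000 nM to 150000 nM.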

Compound 4, half-maximal inhibitory concentration: 63400 nM
For compound 4 the middle estimate is 1.2-fold (0.06 log units) below the measured one; measured number inside the range.
By their numbers in this assay, from the lowest: compound 2; then compounds 4 and 3 (each within the scatter of the next). At a limit, above all of these: compound 1.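

In this assay, replacing the 4-methoxyphenyl with the 2-hydroxyethyl removes the six-membered aromatic ring and adds a hydrogen-bond donor, yet the step is only a 1.6-fold lower number from compound 3 to compound 4 (0.20 log units; within the scatter), so this large change at this carbon leaves the two compounds indistinguishable. A chain without the aromatic ring is also not enough to match compound 2, as the comparison shows a 9.9-fold higher number from compound 2 to compound 4 (1.00 log units; beyond the scatter), with hydroxymethyl in place of ((4-methylphenyl)sulfonyl)amino on the saturated chain carbon. Compound 1 stands at a limit and not at a number, so its step can be read only as an at least 1.5-fold lower number from compound 1 to compound 4 (0.19 log units; that floor lies within the scatter), which sets no firm order: the limit of > 100000 nM in this assay, at which 1 of the 4 values shown sits.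

Going by these compounds, what remains open is which part of the ((4-methylphenyl)sulfonyl)amino group matters, since a free amine or a simple amide on that same chain carbon would help to separate the role of the sulfonyl group from that of the 4-methylphenyl ring. It is also unknown whether a longer chain ending in a hydroxyl group, or a carboxylic acid at this carbon, would differ from compound 4 by more than the usual scatter.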